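A few compounds are considered here, and "the series" means these few. Any claim that something is new, unique, unknown or untested is made for them only; others in the source may bear on it.

Measured in a functional assay on MCF7 cells (Homo sapiens) for antiproliferative activity, read by MTT assay, with a stated time of 72 h; a higher number here means a weaker inhibitor, a lower number a stronger inhibitor:
- Compound 1 `CC1=CC[C@H]2[C@H](CC[C@]2(C)O)C(C)(C)[C@@H]1CC[C@H]1[C@]2(C)CC[C@H](OC(=O)c3ccccc3)C(C)(C)O[C@H]2CC[C@@]1(C)O`: 21000 nM
- Compound 2 `CC1=CC[C@H]2[C@H](CC[C@]2(C)O)C(C)(C)[C@@H]1CC[C@H]1[C@]2(C)CC[C@H](OC(=O)c3ccc(C)cc3)C(C)(C)O[C@H]2CC[C@@]1(C)O`: > 50000 nM (a limit of the assay, not a number)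
- Compound 3 `CC1=CC[C@H]2[C@H](CC[C@]2(C)O)C(C)(C)[C@@H]1CC[C@H]1[C@]2(C)CC[C@H](OC(=O)c3ccc(Cl)cc3)C(C)(C)O[C@H]2CC[C@@]1(C)O`: 24100 nM

Compound 3, which carries a chloro group on its aromatic ring, cannot be told apart from compound 1, since the step of a 1.1-fold higher number from compound 1 to compound 3 (0.06 log units; within the scatter) lies within the scatter. Against compound 2, the picture differs: the data show an at least 2.0-fold lower number from compound 2 to compound 3 (0.31 log units; beyond the scatter). That step and an at least 2.3-fold higher number from compound 1 to compound 2 (0.37 log units; beyond the scatter) both rest on (the limit of > 50000 nM in this assay, at which 1 of the 3 values shown sits).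

Compound 4 `CC1=CC[C@H]2[C@H](CC[C@]2(C)O)C(C)(C)[C@@H]1CC[C@H]1[C@]2(C)CC[C@H](OC(=O)NS(=O)(=O)c3ccc(C)cc3)C(C)(C)O[C@H]2CC[C@@]1(C)O` has not yet been measured. It keeps the shared core, and the change is ((4-methylphenyl)sulfonyl)amino in place of 4-chlorophenyl on a carbonyl carbon. The measured steps only swapped one small group on the aromatic ring, and none of them tests a change this large, so they are a loose guide. Compound 4 does carry a methyl on its aromatic ring, and the methyl step to compound 2 was an at least 2.3-fold higher number from compound 1 to compound 2 (0.37 log units; beyond the scatter), so a small move towards a higher number is expected rather than a large one in either direction. The expected change is a 1.2-fold higher number from compound 3 to compound 4 (0.10 log units; within the scatter). For compound 4 the estimate is 30000 nM, with an expected range of 11000 nM to 80000 nM.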

Compound 4, half-maximal inhibitory concentration: > 50000 nM
Compound 4 ended at the assay's limit; the forecaster's own chance of this, stated with the estimate: 40%; middle value at least 1.6-fold (0.22 log units) from the limit.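

Swapping 4-chlorophenyl for ((4-methylphenyl)sulfonyl)amino on the carbonyl carbon is a far larger change than the earlier swaps of one small ring group, and in this assay compound 4 reaches a limit of the assay, > 50000 nM, rather than a number. Against the compounds with real numbers, the change gives an at least 2.0-fold higher number from compound 3 to compound 4 (0.31 log units; beyond the scatter) and an at least 2.3-fold higher number from compound 1 to compound 4 (0.37 log units; beyond the scatter), so this position did not keep the activity of the phenyl and 4-chlorophenyl compounds when it took the larger group, which holds a hydrogen-bond donor that they lack. The step between compound 2 and compound 4 cannot be read, and the two readable steps give only a minimum size, resting as they do on one shared ceiling: the limit of > 50000 nM in this assay, at which 2 of the 4 values shown sit.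

Compound 2 also carries a methyl on its ring and also sits at the limit, so the loss in compound 4 cannot be assigned to the new sulfonylamino link rather than to that methyl. Also open, as far as these compounds go, is how this position would respond to a sulfonylamino link bearing a plain phenyl or 4-chlorophenyl ring, or to a ring bearing an amine or a carboxylic acid.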